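Rigid Ring Replaces Flexible Chain in a Hydroxamic Acid Series

The compounds below may be only part of what the source reports. "The series", "measured", "known", "first", "only" and "open" are said of these compounds alone.

Measured compounds:
Compound 1, `COc1cc(/C=C/c2ccc(OCCCCC(=O)NO)cc2)cc(OC)c1`, gives 4210 nM in a functional assay on MDA-MB-231 cells (Homo sapiens) for cytotoxicity, read by MTT assay, with a stated time of 48 h; a lower number here means a stronger inhibitor, a higher number a weaker inhibitor.
Compound 2, `COc1cc(/C=C/c2ccc(OCCCCCC(=O)NO)cc2)cc(OC)c1`, gives 3560 nM in this assay.
Compound 3, `COc1cc(/C=C/c2ccc(OCCCCCCCC(=O)NO)cc2)cc(OC)c1`, gives 5050 nM in this assay.

Compound 3 has the highest number of the three, but its nearest neighbour is compound 1 at a 1.2-fold higher number from compound 1 to compound 3 (0.08 log units; within the scatter) and its furthest is compound 2 at a 1.4-fold higher number from compound 2 to compound 3 (0.15 log units; within the scatter), so the three compounds cannot be told apart in this assay. The same holds for a 1.2-fold lower number from compound 1 to compound 2 (0.07 log units; within the scatter).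

Compound 4, `COc1cc(/C=C/c2ccc(OCc3ccc(C(=O)NO)cc3)cc2)cc(OC)c1`, changes the part carrying the hydroxamic acid: 4-(hydroxycarbamoyl)phenyl in place of 6-(hydroxycarbamoyl)hexyl on a saturated chain carbon bound to an oxygen on an aromatic ring. The three measured steps only lengthen or shorten a chain with no ring, and all of them stay within the scatter, so chain length barely matters here. Within the data shown here, none of them swaps a chain for a six-membered aromatic ring, so no measured step speaks directly to the change from compound 3 to compound 4. The flat behaviour across compounds 1, 2 and 3 gives no reason to expect a large move, but the new ring leaves the direction open. Compound 4 is therefore expected to give about 4000 nM in this assay, with a range from 1500 nM to 11000 nM, which means an expected step of a 1.3-fold lower number from compound 3 to compound 4 (0.10 log units; within the scatter).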

Compound 4, half-maximal inhibitory concentration: 6880 nM
The estimate for compound 4 lay 1.7-fold (0.24 log units) below the measured number; measured number inside the range.
By their numbers in this assay, from the lowest: compounds 2, 1, 3 and 4 (each within the scatter of the next).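

Replacing the chain with no ring by 4-(hydroxycarbamoyl)phenyl, on the saturated chain carbon bound to an oxygen on an aromatic ring, goes beyond the changes in chain length seen so far, yet in this assay the steps remain within the scatter (a 1.4-fold higher number from compound 3 to compound 4 (0.13 log units; within the scatter); a 1.9-fold higher number from compound 2 to compound 4 (0.29 log units; within the scatter); a 1.6-fold higher number from compound 1 to compound 4 (0.21 log units; within the scatter)). At this place, then, a six-membered aromatic ring of carbon only and the three chains shown cannot be told apart, so the flat picture now covers a change of chain type as well as chain length. Nothing shown here explains this lack of separation or links it to any property of the ring.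

The compounds shown leave open whether a carboxylic acid in place of the hydroxycarbamoyl group would give a number within the scatter of these four or move it clearly away from them. They also leave open whether adding an amine to the new ring would produce a step beyond the scatter, which none of the changes shown has done so far.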